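The source may hold more compounds than are shown below. What is called first, only, known or untested is meant among the compounds shown, and "the series" means these compounds.

Measured in a functional assay on HGC cells (Homo sapiens) for cytotoxicity, read by MTT assay, with a stated time of 48 h; a lower number here means a stronger inhibitor, a higher number a weaker inhibitor:
- Compound 1 `CC(C)n1c(/C=C2/C(=O)Nc3ccc(Br)cc32)nc2ccccc21`: 12400 nM
- Compound 2 `CCn1c(/C=C2/C(=O)Nc3ccc(Br)cc32)nc2ccccc21`: > 50000 nM

Compound 2 gives > 50000 nM, which is a limit and not a number. This is the limit of > 50000 nM in this assay, at which 1 of the 2 values shown sits. Compound 3 `Cn1c(/C=C2/C(=O)Nc3ccc(Br)cc32)nc2ccccc21` differs from compound 2 by hydrogen in place of methyl on a saturated chain carbon bound to an aromatic nitrogen, which is ethyl to methyl. Within the data shown here, one measured step bears on this, the same kind of change: an at least 4.0-fold higher number from compound 1 to compound 2 (0.60 log units; beyond the scatter). From the compounds shown here alone, its true size is unknown, since it ends at the limit. A further move toward a higher number is expected, but probably none that can be shown beyond the scatter. The expected change is a number no higher from compound 2 to compound 3 (the limit leaves the size open). Compound 3 is estimated at 50000 nM, with an expected range of 20000 nM to 120000 nM.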

Compound 3, half-maximal inhibitory concentration: > 50000 nM
Compound 3: no number, only a limit; the forecaster's own chance of this, stated with the estimate: 65%; the middle value sits exactly at the limit.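

Compound 3 gives only a limit and not a number in this assay, as compound 2 does, and the step between these two compounds cannot be read. Replacing isopropyl with methyl on the aromatic nitrogen gives an at least 4.0-fold higher number from compound 1 to compound 3 (0.60 log units; beyond the scatter), so methyl, like ethyl, does not yield a measurable value here. Of the three compounds, only compound 1, with isopropyl, gives a number, and the other two rest at one limit: the limit of > 50000 nM in this assay, at which 2 of the 3 values shown sit.

From the compounds shown here alone, how far compound 2 and compound 3 lie beyond that limit remains open. So does whether a longer chain, such as butyl, or a chain carrying an amine on the aromatic nitrogen would give a lower number than compound 1.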